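Chain-end change, compound 2 to compound 3

The source may hold more compounds than are shown below. What is called first, only, known or untested is meant among the compounds shown, and "the series" means these compounds.

Measured compounds:
compound 1 `CCC(CC)(c1ccc(OS(=O)(=O)c2ccc(C)cc2)c(C)c1)c1ccc(OCC(=O)C(C)(C)C)c(OCC(=O)C(C)(C)C)c1` — 35%
compound 2 `CCC(CC)(c1ccc(OCCCCCO)c(C)c1)c1ccc(OCC(O)C(C)(C)C)c(OCC(O)C(C)(C)C)c1` — 67%

In an assay on cells for binding affinity to vitamin D3 receptor (Homo sapiens), read by fluorescence, tested at 1 uM (a lower number here means less inhibition, a higher number more inhibition at the concentration tested (going by the name of the read-out)), compound 1 gives 35%, and compound 2 gives 67%. Compound 2 stands highest of the two numbers; compound 1 is the nearer of the two, a number lower by more than the usual scatter. Among the compounds with values here, no step through a single point of difference connects compound 1 and compound 2, so their two values show that gap and nothing more.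

Compound 3 `CCC(CC)(c1ccc(OCCCCC(=O)O)c(C)c1)c1ccc(OCC(O)C(C)(C)C)c(OCC(O)C(C)(C)C)c1` has not been measured. It differs from compound 2 in one place: carboxy in place of hydroxymethyl on a saturated chain carbon, four bonds along the chain from an oxygen on an aromatic ring. Within the data shown here, no measured pair shows a step of this kind, so the size of the step in this assay is open; a step within the scatter, or a modest fall, is expected. Compound 3 is expected to give 60%, between 35% and 85%. The expected step is a number 7 percentage points lower from compound 2 to compound 3 (within the scatter).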

Compound 3, a percentage reported as inhibition, at one concentration (the size of the read-out at that concentration, not a potency): "not active" (no number reported)
No number was reported for compound 3; there is nothing to compare the estimate with.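

In this assay, within the data shown here, compound 3 is recorded as not active, without a number, and no step from compound 2 to compound 3 can be read. No evidence at hand bears on this result. The compounds shown leave open how large a change carboxy in place of hydroxymethyl brings.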